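This account rests on a few compounds, and the source may have more. Where it says the series, first, only, none or still open, it means among the compounds named here.

Measured compounds:
- compound 1, `COc1cc(C)cc(-c2c(-c3ccnc(-c4ccc(C(C)=O)cc4)c3)cnn2CC#N)c1`, > 100000 nM
- compound 2, `Cc1cc(O)cc(-c2nn(CC#N)cc2-c2ccnc(-c3ccc(Oc4ccccc4)cc3)c2)c1`, 5730 nM
- compound 3, `Cc1cc(O)cc(-c2nn(CC#N)cc2-c2ccnc(-c3ccc(N(C)C)cc3)c2)c1`, 20400 nM

The read-out throughout is a functional assay on M14 cells (Homo sapiens) for inhibition, read by sulforhodamine B assay, with a stated time of 48 h; on this read-out higher numbers stand for lower toxicity in this test and lower numbers for higher toxicity in this test. For compound 1 the result is only a limit of the assay, > 100000 nM, not a number, so compound 1 stands at the edge of what this assay can report; this is the limit of > 100000 nM in this assay, at which 1 of the 3 values shown sits. Compound 2 gives 5730 nM and compound 3 gives 20400 nM.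

Compound 4, `COc1cc(C)cc(-c2c(-c3ccnc(-c4ccc(N(C)C)cc4)c3)cnn2CC#N)c1`, differs from compound 1 by one change: dimethylamino in place of acetyl on an aromatic carbon. Going by the values given here, no measured pair shows exactly this exchange. The closest is a 3.6-fold higher number from compound 2 to compound 3 (0.55 log units; beyond the scatter), where a dimethylamino group also enters on an aromatic carbon, though in place of phenoxy rather than acetyl. Since compound 1 sits at the limit, a step in either direction may stay hidden. Compound 4 is expected to fall near that limit, with an at least 1.4-fold lower number from compound 1 to compound 4 (0.15 log units; that floor lies within the scatter) as the estimated step. Compound 4 is therefore estimated at 70000 nM, within a range from 15000 nM to 300000 nM.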

Compound 4, concentration lethal to 50% of the cells: > 100000 nM
Compound 4 ended at the assay's limit; the forecaster's own chance of this, stated with the estimate: 55%; middle value at least 1.4-fold (0.15 log units) from the limit.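

Compound 1 and compound 4 both end at a limit of this assay rather than at a number, so no step between them can be read: the limit of > 100000 nM in this assay, at which 2 of the 4 values shown sit.

The compounds shown leave open whether dimethylamino in place of acetyl changes the read-out at all.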